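Swapping an Amide for a Sulfonamide on the Shared Core

This account rests on a few compounds, and the source may have more. Where it says the series, first, only, none or still open, it means among the compounds named here.

Compound 1 `CN(C(=O)C(C)(C)C)c1ccc2[nH]c(-c3n[nH]c4ccccc34)cc2n1` — 22200 nM
Compound 2 `CN(C(=O)c1ccco1)c1ccc2[nH]c(-c3n[nH]c4ccccc34)cc2n1` — 28200 nM

In a functional assay on SMMC-7721 cells (Homo sapiens) for antiproliferative activity, read by MTT assay, with a stated time of 72 h (a higher number here means a weaker inhibitor, a lower number a stronger inhibitor), compound 2 gives the highest of the two numbers, with compound 1 nearest at a 1.3-fold higher number from compound 1 to compound 2 (0.10 log units; within the scatter). Compound 3 `CN(c1ccc2[nH]c(-c3n[nH]c4ccccc34)cc2n1)S(=O)(=O)c1ccccc1` differs from compound 2 by phenylsulfonyl in place of (furan-2-yl)carbonyl on a nitrogen on an aromatic ring. Among the compounds with values here, the only measured step, a 1.3-fold higher number from compound 1 to compound 2 (0.10 log units; within the scatter), swaps one carbonyl substituent for another and is within the scatter, whereas compound 3 carries a sulfonyl in place of the carbonyl, a change no measured pair covers. Compound 3 is therefore expected to show no step beyond the scatter, estimated at 25000 nM (range 8000 nM to 80000 nM), a step of a 1.1-fold lower number from compound 2 to compound 3 (0.05 log units; within the scatter).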

Compound 3, half-maximal inhibitory concentration: 12000 nM
The estimate for compound 3 lay 2.1-fold (0.32 log units) above the measured number, within the range that was stated.
By their numbers in this assay, from the lowest: compounds 3, 1 and 2 (each within the scatter of the next, the first and the last beyond it).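

In this assay, within the data shown here, the swap of (furan-2-yl)carbonyl for phenylsulfonyl on the nitrogen gives a 2.4-fold lower number from compound 2 to compound 3 (0.37 log units; beyond the scatter) and so yields the first step beyond the scatter, showing that this position can respond to the group it carries. Replacing (tert-butyl)carbonyl gives a 1.9-fold lower number from compound 1 to compound 3 (0.27 log units; within the scatter) and stays within the scatter, so the sulfonamide is not clearly set apart from both amides. Nothing given here accounts for the difference.

On these data alone, whether the sulfonyl or the phenyl ring matters more remains open. A benzoyl or a methylsulfonyl group on the same nitrogen would separate the two.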